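This account rests on a few compounds, and the source may have more. Where it says the series, first, only, none or still open, it means among the compounds named here.

Compound 3 `Cc1ccc(NC(=O)NC(=O)c2ccc(OCc3ccccc3F)cc2)cc1-c1nc2ccccc2[nH]1` is, in a functional assay on MGC-803 cells (Homo sapiens) for inhibition, read by MTT assay, with a stated time of 48 h (on this read-out lower numbers stand for stronger inhibition and higher numbers for weaker inhibition), the compound with the lowest of the two numbers shown, giving 2520 nM. Its nearest neighbour is compound 2 `Cc1ccc(NC(=O)NC(=O)c2ccc(OCc3cccc(C(F)(F)F)c3)cc2)cc1-c1nc2ccccc2[nH]1`, which in this assay gives 13100 nM; the change from 3-(trifluoromethyl)phenyl to 2-fluorophenyl on a saturated chain carbon bound to an oxygen on an aromatic ring brought a 5.2-fold lower number from compound 2 to compound 3 (0.72 log units; beyond the scatter). Compound 1 `Cc1ccc(NC(=S)NC(=O)c2ccc(OCc3cccc(F)c3)cc2)cc1-c1nc2ccccc2[nH]1`, a thiourea analogue, gives only a limit in this assay, > 100000 nM, which is the limit of > 100000 nM in this assay, at which 1 of the 3 values shown sits.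

Compound 4 `Cc1ccc(NC(=O)NC(=O)c2ccc(OCc3ccc(Cl)c(Cl)c3)cc2)cc1-c1nc2ccccc2[nH]1` differs from compound 3 in one place: 3,4-dichlorophenyl in place of 2-fluorophenyl on a saturated chain carbon bound to an oxygen on an aromatic ring. Going by the values given here, the only measured step that touches this place was modest and beyond the scatter: a 5.2-fold lower number from compound 2 to compound 3 (0.72 log units; beyond the scatter). Because compound 2 gives 13100 nM with 3-(trifluoromethyl)phenyl, which like 3,4-dichlorophenyl carries its substitution away from where 2-fluorophenyl carries its fluorine, a rise in the number is expected, roughly a 2.4-fold higher number from compound 3 to compound 4 (0.38 log units; beyond the scatter). Compound 4 is therefore estimated at 6000 nM in this assay, between 2000 nM and 20000 nM.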

Compound 4, half-maximal inhibitory concentration: 6080 nM
The estimate for compound 4 lay 1.0-fold (0.01 log units) below the measured number; low and high end bracket the measured number.
By their numbers in this assay, from the lowest: compound 3; then compound 4; then compound 2. At a limit, above all of these: compound 1.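

In this assay, 3,4-dichlorophenyl on a saturated chain carbon bound to an oxygen on an aromatic ring gave a 2.4-fold higher number from compound 3 to compound 4 (0.38 log units; beyond the scatter) against 2-fluorophenyl, and a 2.2-fold lower number from compound 2 to compound 4 (0.33 log units; beyond the scatter) against 3-(trifluoromethyl)phenyl, so the new group falls in the middle of the order rather than extending it at either end. This place therefore separates three substituted phenyl groups into three distinct levels, with every step beyond the usual scatter but none larger than modest, and 2-fluorophenyl in compound 3 remains the lowest of the three. Nothing measured here accounts for these differences.

Going by these compounds alone, compound 1 gives only a limit and differs from the other compounds in more than one place, so no step to it can be read. The compounds shown leave open how an unsubstituted phenyl, a 2-chlorophenyl, or a phenyl carrying an amine or a carboxylic acid would read at this place, and whether the order of these three groups would hold in a longer series.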